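Trifluoromethyl in place of nitro on compound 3

The source may hold more compounds than are shown below. What is called first, only, known or untested is meant among the compounds shown, and "the series" means these compounds.

compound 1 `O=C1/C(=C/c2ccncc2)CN(S(=O)(=O)c2ccccc2)C/C1=C\c1ccccc1C(F)(F)F`: 12300 nM
compound 2 `Cc1ccc(S(=O)(=O)N2C/C(=C\c3ccncc3)C(=O)/C(=C/c3ccccc3C(F)(F)F)C2)cc1`: 12800 nM
compound 3 `O=C1/C(=C/c2ccncc2)CN(S(=O)(=O)c2ccc([N+](=O)[O-])cc2)C/C1=C\c1ccccc1C(F)(F)F`: 18600 nM

All three compounds were tested in an ADME assay on L02 cells (Homo sapiens) for cytotoxicity, read by MTT assay, with a stated time of 24 h; on this read-out lower numbers stand for stronger inhibition and higher numbers for weaker inhibition. Compound 3, at 18600 nM, stands within the scatter of both others, so none of the three separates from the rest. Compound 4 `O=C1/C(=C/c2ccncc2)CN(S(=O)(=O)c2ccc(C(F)(F)F)cc2)C/C1=C\c1ccccc1C(F)(F)F` has not yet been measured. Its difference from compound 3 is trifluoromethyl in place of nitro on an aromatic carbon.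

Within the data shown here, three measured steps bear on this change, each a swap on an aromatic carbon: a 1.5-fold higher number from compound 1 to compound 3 (0.18 log units; within the scatter), a 1.5-fold higher number from compound 2 to compound 3 (0.16 log units; within the scatter) and a 1.0-fold higher number from compound 1 to compound 2 (0.02 log units; within the scatter). All of them stay within the scatter, so no step beyond the scatter, in either direction, is expected in this assay here. The estimated step is a 1.3-fold lower number from compound 3 to compound 4 (0.11 log units; within the scatter), which is expected to remain within the scatter. The expected value for compound 4 is 14500 nM, with an estimated range from 8500 nM to 24000 nM.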

Compound 4, half-maximal inhibitory concentration: 13800 nM
Estimate against measurement, compound 4: 1.1-fold (0.02 log units) above; the range from low to high includes it.
By their numbers in this assay, from the lowest: compounds 1, 2, 4 and 3 (each within the scatter of the next).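

In this assay, trifluoromethyl on this aromatic carbon, para to a large group, stays within the scatter of each group seen there before: nitro (a 1.3-fold lower number from compound 3 to compound 4 (0.13 log units; within the scatter)), methyl (a 1.1-fold higher number from compound 2 to compound 4 (0.03 log units; within the scatter)) and hydrogen (a 1.1-fold higher number from compound 1 to compound 4 (0.05 log units; within the scatter)). The earlier compounds had shown this flat picture only for hydrogen, methyl and nitro; it now also holds for a group with no hydrogen-bond acceptors in place of nitro, which has them, so all four compounds remain inseparable at this place. No measurement shown here accounts for this flat result.

Going by these compounds, whether an amine, a carboxylic acid or a longer chain at this place would also stay within the scatter remains open. So does the effect of any change elsewhere on the shared core, which stays the same in all four compounds.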